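Demethylating the Methoxy Group of a Pyrazole Diaryl Urea

The compounds below may be only part of what the source reports. "The series", "measured", "known", "first", "only" and "open" are said of these compounds alone.

Compound 2 `COc1cc(-c2nn(-c3cccc(NC(=O)Nc4cc(C(F)(F)F)cc(C(F)(F)F)c4)c3)cc2-c2ccncc2)ccc1Cl` gives the lowest of the two numbers available in a functional assay on OVCAR-5 cells (Homo sapiens) for inhibition, read by sulforhodamine B assay, with a stated time of 48 h (a lower number here means a stronger inhibitor of growth, a higher number a weaker inhibitor of growth), at 2470 nM. Its nearest neighbour is compound 3 `COc1cc(-c2nn(-c3cccc(NC(=O)Nc4cccc(C(F)(F)F)c4)c3)cc2-c2ccncc2)ccc1Cl`, which in this assay gives 6450 nM. Compound 1 `O=C(Nc1cccc(-n2cc(-c3ccncc3)c(-c3ccc(Cl)c(O)c3)n2)c1)Nc1cccc(C(F)(F)F)c1` in this assay reaches only a limit of the assay, > 32500 nM. The step of a 2.6-fold higher number from compound 2 to compound 3 (0.42 log units; beyond the scatter) arises from hydrogen in place of trifluoromethyl on an aromatic carbon, and the step of an at least 5.0-fold lower number from compound 1 to compound 3 (0.70 log units; beyond the scatter) from methyl in place of hydrogen on an oxygen on an aromatic ring.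

Compound 4 `O=C(Nc1cccc(-n2cc(-c3ccncc3)c(-c3ccc(Cl)c(O)c3)n2)c1)Nc1cc(C(F)(F)F)cc(C(F)(F)F)c1` has not yet been measured. It differs from compound 2 by hydrogen in place of methyl on an oxygen on an aromatic ring, that is, methoxy to hydroxy, or 4-chloro-3-methoxyphenyl to 4-chloro-3-hydroxyphenyl. This is the reverse of the change that produced the step of an at least 5.0-fold lower number from compound 1 to compound 3 (0.70 log units; beyond the scatter), so a higher number, of at least that size, is expected in this assay. Compound 1 sits at the limit of > 32500 nM in this assay, at which 1 of the 3 values shown sits, so compound 4 may also reach only a limit. Compound 4 is expected to give 16000 nM in this assay, within a range from 6000 nM to 60000 nM. The expected step is a 6.5-fold higher number from compound 2 to compound 4 (0.81 log units; beyond the scatter).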

Compound 4, concentration for total growth inhibition: 2030 nM
Beside the measured number, compound 4's estimate is 7.9-fold (0.90 log units) above it; the measured number lies below the stated range.
By their numbers in this assay, from the lowest: compounds 4 and 2 (each within the scatter of the next); then compound 3. At a limit, above all of these: compound 1.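

In this assay, methoxy to hydroxy on the core of compound 2 gives a 1.2-fold lower number from compound 2 to compound 4 (0.09 log units; within the scatter), so a methyl on this oxygen is not required for growth inhibition on this core. The earlier pair had suggested otherwise, and the same change proves to depend on the core that carries it: the same change on two cores in this assay, an at least 5.0-fold lower number (0.70 log units; beyond the scatter) from compound 1 to compound 3 and a 1.2-fold higher number (0.09 log units; within the scatter) from compound 4 to compound 2, at least 6.1-fold (0.78 log units) apart, beyond the scatter of two such steps Adding trifluoromethyl to the hydroxy core gives an at least 16-fold lower number from compound 1 to compound 4 (1.20 log units; beyond the scatter), and this step differs from the one seen with the methoxy group present: the same change on two cores in this assay, a 2.6-fold higher number (0.42 log units; beyond the scatter) from compound 2 to compound 3 and an at least 16-fold higher number (1.20 log units; beyond the scatter) from compound 4 to compound 1, at least 6.1-fold (0.78 log units) apart, beyond the scatter of two such steps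

From the compounds shown here alone, compound 1 gives > 32500 nM, a limit of the assay, so the true size of both steps from it stays open. Also open, going by these compounds, is whether an ethyl group or a longer chain on this oxygen, or an amine in place of the hydroxy, would match compound 4.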